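Low toxicity at the amide end of the series

This account rests on a few compounds, and the source may have more. Where it says the series, first, only, none or still open, it means among the compounds named here.

In an ADME assay on BE(2)-C cells (Homo sapiens) for cytotoxicity, read by MTT assay, with a stated time of 20 h (on this read-out lower numbers stand for higher toxicity in this test and higher numbers for lower toxicity in this test), compound 1 (`O=C(NCc1ccncc1)C1CCN(C(=O)c2cc3ccccc3n2Cc2ccc(Cl)cc2)CC1`) gives > 100000 nM as a limit of the assay and not a number. Among the measured compounds shown here, compound 2 (`O=C(c1cc2ccccc2n1Cc1ccc(Cl)cc1)N1CCC(C(=O)N2CCC[C@H]2CO)CC1`) gives 98900 nM as the only true number so far. Compound 3 (`O=C(c1cc2ccccc2n1Cc1ccc(Cl)cc1)N1CCC(C(=O)N2CCCC2)CC1`) has hydrogen in place of hydroxymethyl on a saturated ring carbon, turning 2-(hydroxymethyl)pyrrolidin-1-yl into pyrrolidin-1-yl. For the measured compounds named here, one measured step bears on this, a number no higher from compound 1 to compound 2 (the limit leaves the size open) at the same carbonyl carbon, and its size stays open because of the limit of > 100000 nM in this assay, at which 1 of the 2 values shown sits, in the data. It therefore gives no evidence for a large change in this assay. The step of a 1.0-fold lower number from compound 2 to compound 3 (0.02 log units; within the scatter) is expected to stay within the usual scatter, with no direction favoured. A reading at the limit is also possible. The estimate for compound 3 is 95000 nM with an expected range from 45000 nM to 180000 nM in this read-out.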

Compound 3, half-maximal cytotoxic concentration: 65600 nM
Compound 3: middle estimate off by 1.4-fold (0.16 log units), on the high side, and the stated range covers the measured number.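

In this assay, among the compounds shown here, the hydroxymethyl on the saturated ring carbon gives the first step at this end of the series with true numbers at both ends: a 1.5-fold lower number from compound 2 to compound 3 (0.18 log units; within the scatter). Taking hydroxymethyl down to hydrogen therefore gives no readable difference in this test, so the hydroxymethyl cannot be tied to the numbers seen for these compounds. The step of an at least 1.5-fold lower number from compound 1 to compound 3 (0.18 log units; that floor lies within the scatter) gives only a floor, and its true size stays open: the limit of > 100000 nM in this assay, at which 1 of the 3 values shown sits.

Going by these compounds, whether an amine, a carboxylic acid or a longer chain in place of the hydroxymethyl would give a step beyond the scatter remains open. Also open, on these data alone, is whether changes on the shared core would move the number further than any change at this amide end.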